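The source may report more compounds than this note shows. Statements on the series, on what has been measured and on what is new or still open speak of the compounds shown alone.

Measured compounds:
- compound 1 `C[C@@H](Cn1ccc(-c2ccc(C#N)c(Cl)c2)n1)NC(=O)c1ccccc1` — in an ADME assay on PC-3 cells (Homo sapiens) for cytotoxicity, read by CCK-8 assay, with a stated time of 6 days (a lower number here means a stronger inhibitor, a higher number a weaker inhibitor), compound 1 gives > 30000 nM, which is a limit of the assay and not a number.
- compound 2 `CC(O)c1cccc(C(=O)N[C@@H](C)Cn2ccc(-c3ccc(C#N)c(Cl)c3)n2)c1` — in this assay compound 2 gives > 30000 nM, again a limit rather than a number.
- compound 3 `COc1ccc(C(=O)N[C@@H](C)Cn2ccc(-c3ccc(C#N)c(Cl)c3)n2)cc1` — in this assay compound 3 gives > 30000 nM, also a limit.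

All three measured compounds share the same core and differ only in the group attached to the amide carbonyl. None of them reached a numerical read-out: every value sits at the same ceiling, as the limit of > 30000 nM in this assay, at which 3 of the 3 values shown sit, shows. The three structural steps among them cannot be sized: a step that the two limits leave unreadable from compound 1 to compound 2, a step that the two limits leave unreadable from compound 1 to compound 3 and a step that the two limits leave unreadable from compound 2 to compound 3 all remain unreadable, and compound 3 stands simply at the limit alongside the other two.

Compound 4 `COC(=O)/C=C/C(=O)N[C@@H](C)Cn1ccc(-c2ccc(C#N)c(Cl)c2)n1` is the next member. Compared with compound 3, the change is 2-(methoxycarbonyl)ethenyl in place of 4-methoxyphenyl on a carbonyl carbon. For the measured compounds named here, no measured step speaks directly to this exchange, since every comparison so far ended in two limits. Going by the values given here, the only guidance is that three different amide substituents all gave no measurable cytotoxicity in this assay.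

On that basis compound 4 is expected to behave the same way, with a number no higher from compound 3 to compound 4 (the limit leaves the size open) most likely meaning no readable change. The estimate for compound 4 is 30000 nM, within a range of 8000 nM to 120000 nM, and the most probable outcome is that this assay again reports only a limit.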

Compound 4, half-maximal inhibitory concentration: > 30000 nM
Compound 4: no number, only a limit; the forecaster's own chance of this, stated with the estimate: 80%; the middle value sits exactly at the limit.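

For the compounds shown here, no step from compound 1, compound 2 or compound 3 to compound 4 can be read in this assay, since all four values are limits and not numbers: the limit of > 30000 nM in this assay, at which 4 of the 4 values shown sit.

The compounds shown leave open whether any group on the carbonyl carbon of the shared core would give a readable value, and how these four groups truly compare.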